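Methyl addition on the benzyl ring: cytotoxicity outlook

The source may report more compounds than this note shows. Statements on the series, on what has been measured and on what is new or still open speak of the compounds shown alone.

Measured compounds:
compound 1 `CN(c1ccc(NC(=O)c2cc(C(F)(F)F)cc(C(F)(F)F)c2)cc1OCc1cccc(C(F)(F)F)c1)S(C)(=O)=O` — > 500000 nM
compound 2 `CN(c1ccc(NC(=O)c2ccc(C(F)(F)F)cc2C(F)(F)F)cc1OCc1cccc(C(F)(F)F)c1)S(C)(=O)=O` — > 500000 nM
compound 3 `Cc1ccc(C(F)(F)F)cc1COc1cc(NC(=O)c2cc(C(F)(F)F)cc(C(F)(F)F)c2)ccc1N(C)S(C)(=O)=O` — > 500000 nM

In an ADME assay on HEK293 cells (Homo sapiens) for cytotoxicity, read by MTT assay, with a stated time of 48 h (a higher number here means a weaker inhibitor, a lower number a stronger inhibitor), compound 1 reaches only the limit of the assay, > 500000 nM. In this assay compound 2 also gives only a limit, > 500000 nM. Compound 3 likewise stops at a limit in this assay, > 500000 nM. Compound 2 therefore stands among values that are all limits, and no ordering among the three can be read.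

Compound 4 `Cc1ccc(C(F)(F)F)cc1COc1cc(NC(=O)c2ccc(C(F)(F)F)cc2C(F)(F)F)ccc1N(C)S(C)(=O)=O` is not yet measured. It differs from compound 2 by methyl in place of hydrogen on an aromatic carbon. Among the compounds with values here, the one measured step of the same kind, a step that the two limits leave unreadable from compound 1 to compound 3, cannot be sized because of the limit of > 500000 nM in this assay, at which 3 of the 3 values shown sit. Within the data shown here, no other pair bears on the change.

The expectation is accordingly that compound 4 stays at the limit as well, with a step that the limit leaves unreadable from compound 2 to compound 4 that is not readable against the scatter. The estimated value for compound 4 is 600000 nM, within 250000 nM to 3000000 nM.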

Compound 4, half-maximal inhibitory concentration: > 500000 nM
Compound 4: a limit, no number; the forecaster's own chance of this, stated with the estimate: 85%; the middle value does not contradict the limit.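

The pair compound 2 and compound 4 gives no readable step in this assay, because both stop at a limit: the limit of > 500000 nM in this assay, at which 4 of the 4 values shown sit.

The compounds shown leave open whether methyl in place of hydrogen on an aromatic carbon alters this read-out at all; none of the four gives a number.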